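The source may hold more compounds than are shown below. What is called first, only, known or untested is meant among the compounds shown, and "the series" means these compounds.

Measured so far:
compound 1 `CCOC(=O)C1=C(C)NC(=S)NC1c1ccc(O)c(O)c1`: 25 ug/mL
compound 2 `CCOC(=O)C1=C(C)NC(=S)NC1c1ccc(F)cc1`: 1.7 ug/mL

In a functional assay on PC-3 cells (Homo sapiens) for inhibition, read by sulforhodamine B assay, with a stated time of 48 h (a higher number here means a weaker inhibitor of growth, a lower number a stronger inhibitor of growth), compound 2 has the lower of the two numbers, at 1.7 ug/mL, and its gap to compound 1 lies beyond the usual scatter. Compound 3 `CCOC(=O)C1=C(C)NC(=S)NC1c1ccc(OC)cc1` carries methoxy in place of fluoro on an aromatic carbon, para to a large group (methoxy in place of fluoro on an aromatic carbon). Among the measured compounds shown here, no measured step covers this change, so the expectation is loose: a modest move towards a higher number in this assay, possibly no larger than the scatter. The expected step is a 2.4-fold higher number from compound 2 to compound 3 (0.37 log units; beyond the scatter). For compound 3 the estimated value is 4 ug/mL, with an expected range of 1.2 ug/mL to 15 ug/mL.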

Compound 3, concentration for 50% growth inhibition: 5.5 ug/mL
The estimate for compound 3 lay 1.4-fold (0.14 log units) below the measured number, within the range that was stated.
By their numbers in this assay, from the lowest: compound 2; then compound 3; then compound 1.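

Among the compounds shown here, on an aromatic carbon para to a large group, the first single-place comparison in this assay shows that methoxy in place of fluoro gives a 3.2-fold higher number from compound 2 to compound 3 (0.51 log units; beyond the scatter). The number at this position therefore responds to this exchange on an otherwise unchanged core, and of these two groups fluoro carries the lower number. No measurement shown accounts for the step.

Still open, as far as these compounds go, is how an amine, a carboxylic acid or a longer chain such as butoxy would read at this position. Two groups at one position give no trend.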